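Ring amine swaps on the shared core: outlook for compound 4

A few compounds are considered here, and "the series" means these few. Any claim that something is new, unique, unknown or untested is made for them only; others in the source may bear on it.

Measured in an assay on isolated protein for displacement of a labelled ligand from metabotropic glutamate receptor 5 (Homo sapiens), with a stated time of 60 min, tested at 1 uM; on this read-out lower numbers stand for less inhibition and higher numbers for more inhibition at the one concentration tested (going by the name of the read-out):
compound 1 `CC1CCN(c2c(S(=O)(=O)c3ccccc3)cnc3ccccc23)CC1`: 89.2%
compound 2 `CCOC(=O)C1CCN(c2c(S(=O)(=O)c3ccccc3)cnc3ccccc23)CC1`: 33%
compound 3 `CN1CCN(c2c(S(=O)(=O)c3ccccc3)cnc3ccccc23)CC1`: 7.7%

Compound 3 stands lowest of the three numbers in this assay; compound 2 is its nearest neighbour, and compound 1 lies furthest above it. Both measured steps from compound 1 are large and beyond the scatter: a number 56.2 percentage points lower from compound 1 to compound 2 (beyond the scatter), and a number 81.5 percentage points lower from compound 1 to compound 3 (beyond the scatter).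

Compound 4 `O=S(=O)(c1ccccc1)c1cnc2ccccc2c1N1CCCCC1` is not yet measured. It differs from compound 3 as follows: piperidin-1-yl in place of 4-methylpiperazin-1-yl on an aromatic carbon. Within the data shown here, the step that bears on this is the one from compound 1 to compound 3, where 4-methylpiperazin-1-yl replaced 4-methylpiperidin-1-yl and the number fell by a number 81.5 percentage points lower from compound 1 to compound 3 (beyond the scatter). Among the measured compounds shown here, compound 4 reverses that ring change but also lacks the methyl on the saturated ring; no measured step shows the methyl alone, so part of the recovery is uncertain. A large rise beyond the scatter is therefore expected, a number 60.3 percentage points higher from compound 3 to compound 4 (beyond the scatter), without necessarily reaching the number of compound 1. Compound 4 is estimated at 68% in this assay, with a range from 38% to 92%.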

Compound 4, a percentage reported as inhibition, at one concentration (the size of the read-out at that concentration, not a potency): 71.4%
For compound 4 the middle estimate is 3.4 percentage points below the measured one; the range from low to high includes it.
By their numbers in this assay, from the lowest: compound 3; then compound 2; then compound 4; then compound 1.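

In this assay, the step of a number 63.7 percentage points higher from compound 3 to compound 4 (beyond the scatter) shows that the high level does not depend on the methyl on the saturated ring, since piperidin-1-yl in place of 4-methylpiperazin-1-yl restores most of what the earlier ring change lost. Among these compounds, the methyl on the saturated ring carbon can now be read by itself for the first time: the step of a number 17.8 percentage points lower from compound 1 to compound 4 (beyond the scatter) is modest but beyond the scatter, so hydrogen at that carbon keeps most of the inhibition while methyl adds a further measurable amount. The step of a number 38.4 percentage points higher from compound 2 to compound 4 (beyond the scatter) places plain hydrogen well above ethoxycarbonyl on the same carbon, so in these three compounds the substituent at that carbon can push the number either way from the unsubstituted ring, up with methyl and down with ethoxycarbonyl.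

Still open, as far as these compounds go, is how a hydroxyl, a primary amine, a carboxylic acid or a longer chain such as ethyl or propyl would behave on that saturated ring carbon, and how morpholin-4-yl or an unsubstituted piperazin-1-yl would compare with piperidin-1-yl on the aromatic carbon. No measurement shown here gives an explanation for any of these steps.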